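From 4-Fluoro-3-methylbenzyl to 3-Fluorobenzyl on Compound 2

The source may report more compounds than this note shows. Statements on the series, on what has been measured and on what is new or still open speak of the compounds shown alone.

Three compounds built on a shared core have been examined in a physicochemical assay for lipophilicity, at pH 7.4 (a higher number here means a more lipophilic compound, a lower number a more polar compound), so far. They are compound 1 (`Cc1cc(S(=O)(=O)NCCCC[C@@H](Nc2cc(C)c(F)c(C)c2)C(=O)NO)ccc1F`), compound 2 (`Cc1cc(CNCCCC[C@@H](Nc2cc(C)c(F)c(C)c2)C(=O)NO)ccc1F`) and compound 3 (`Cc1cc(NC(=O)NCCCC[C@@H](Nc2cc(C)c(F)c(C)c2)C(=O)NO)ccc1F`). Compound 1 gives < 3 as a limit of the assay and not a number. Compound 2 gives < 3 as a limit too. Compound 3 likewise gives < 3 as a limit. Compound 2 therefore has no number of its own and stands level with the other two only as far as the shared limit goes (the limit of < 3 in this assay, at which 3 of the 3 values shown sit).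

The next compound is compound 4 (`Cc1cc(N[C@H](CCCCNCc2cccc(F)c2)C(=O)NO)cc(C)c1F`), which differs from compound 2 in one place (3-fluorophenyl in place of 4-fluoro-3-methylphenyl on a saturated chain carbon bound to an amine nitrogen). Here 3-fluorophenyl stands in place of 4-fluoro-3-methylphenyl on a saturated chain carbon bound to an amine nitrogen, so that 4-fluoro-3-methylbenzyl becomes 3-fluorobenzyl. Among the compounds with values here, no measured pair shows this change, so its size in this assay can only be estimated. A modest downward step is expected (a step that the limit leaves unreadable from compound 2 to compound 4) and the result will most probably be reported only as a limit again. For compound 4 the estimated value is 2.5 with an expected range from 1.8 to 3 around it.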

Compound 4, distribution coefficient: < 3
Compound 4: only a limit was reported; the forecaster's own chance of this, stated with the estimate: 85%; the middle value does not contradict the limit.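

In this assay compound 4 gives < 3 as a limit of the assay and not a number. Within the data shown here, compound 2 also stands only at a limit, so no step between compound 2 and compound 4 can be read. The compounds shown leave open what number any of the four would carry in this assay and how large the change from 4-fluoro-3-methylbenzyl to 3-fluorobenzyl is there.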